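Side-chain amine change from compound 2 to compound 4

A few compounds are considered here, and "the series" means these few. Any claim that something is new, unique, unknown or untested is made for them only; others in the source may bear on it.

Measured so far:
compound 1, `COc1cc2ccc(=O)oc2cc1OCC(=O)c1ccccc1`: 83.6%
compound 2, `COc1cc2ccc(=O)oc2cc1OCC(O)CN1CCN(C)CC1`: 3.4%
compound 3, `COc1cc2ccc(=O)oc2cc1OCCNC(C)C`: 0.1%

All three compounds share one core and differ only in the side chain on the ether oxygen. For the measured compounds named here, in a functional assay on HUVEC cells (Homo sapiens) for inhibition, read by MTT assay, with a stated time of 24 h, tested at 100 uM (on this read-out lower numbers stand for less inhibition of growth and higher numbers for more inhibition of growth at the one concentration tested), compound 1 gives 83.6% and is the only member with a high number. Compound 2 stands second highest of the three numbers. Its nearest neighbour is compound 3, whose number lies a little lower, within the scatter, so no order between compound 2 and compound 3 can be read. Its furthest neighbour is compound 1, whose number lies far higher, beyond the scatter.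

Compound 4, `COc1cc2ccc(=O)oc2cc1OCC(O)CNC(C)C`, has not been measured in this assay. It differs from compound 2 in one place: isopropylamino in place of 4-methylpiperazin-1-yl on a saturated chain carbon, two bonds along the chain from an oxygen on a saturated carbon. The hydroxyl on the chain is kept.

Going by the values given here, no step between measured compounds is recorded for this change. Compound 3 also carries an isopropylamino group on its chain and gives 0.1%, a number within the scatter of compound 2. On this basis the expected step is a number 0.4 percentage points lower from compound 2 to compound 4 (within the scatter), none beyond the scatter. Compound 4 is therefore estimated at 3%, with a range from 0% to 15%.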

Compound 4, percent growth inhibition at one concentration: 6.3%
Beside the measured number, compound 4's estimate is 3.3 percentage points below it; measured number inside the range.
By their numbers in this assay, from the lowest: compounds 3, 2 and 4 (each within the scatter of the next); then compound 1.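

In this assay, isopropylamino in place of 4-methylpiperazin-1-yl, with the chain hydroxyl kept, gives a number 2.9 percentage points higher from compound 2 to compound 4 (within the scatter), so this pair separates neither the ring-bearing group from the open-chain amine nor the two groups in any order. With isopropylamino held constant, 1-hydroxy-2-(isopropylamino)ethyl in place of (isopropylamino)methyl gives a number 6.2 percentage points higher from compound 3 to compound 4 (within the scatter), so this change of chain, which brings in the hydroxyl, also produces no resolved difference at the one concentration tested. No measured evidence bears on the reason for these readings.

For the compounds shown here, no single-place step links compound 1 to compound 2, compound 3 or compound 4, so the high number of compound 1 cannot be assigned to any one feature of its side chain. Also open, as far as these compounds go, is whether a morpholine in place of isopropylamino, or a carboxylic acid at the end of the chain, would give a number beyond the scatter of compound 4.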